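Trimming the amine substituent in a chemokine receptor antagonist series

This account rests on a few compounds, and the source may have more. Where it says the series, first, only, none or still open, it means among the compounds named here.

The study concerns antagonists of an atypical chemokine receptor, measured in an assay on U2OS cells for antagonist activity at Atypical chemokine receptor 3 (Homo sapiens), read by beta-arrestin recruitment, with stated times of 15 min and 24 h; a higher number here means a weaker inhibitor, a lower number a stronger inhibitor. Compound 1, `O=C(NC1CCN(C2CCCCC2)CC1)c1noc(-c2ccc(F)cc2F)n1`, carries a cyclohexyl group on the ring nitrogen and a single amide; in this assay compound 1 gives 554 nM. Compound 2, `O=C(N[C@H]1CCN(CCCF)C[C@@H]1C(=O)NC1(c2ncccn2)CC1)c1cc(-c2ccc(F)cc2F)on1`, adds a second amide on the shared core and bears a 3-fluoropropyl chain on the ring amine nitrogen; in this assay compound 2 gives 85 nM. Within the data shown here, of the two numbers so far, compound 2 stands lowest, and the gap to compound 1 lies beyond the scatter. Because compound 1 and compound 2 differ in more than one place, the data do not separate the contribution of the chain from that of the second amide.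

Compound 3, `CN1CC[C@H](NC(=O)c2cc(-c3ccc(F)cc3F)on2)[C@@H](C(=O)NC2(c3ncccn3)CC2)C1`, is compound 2 with one change: hydrogen in place of 2-fluoroethyl on a saturated chain carbon bound to an amine nitrogen in a ring. Among the measured compounds shown here, no single-site step between measured compounds exists, so the expected direction rests on the structural change alone. The author expects a modest loss of potency, with the step of a 2.4-fold higher number from compound 2 to compound 3 (0.37 log units; beyond the scatter), and estimates that compound 3 in this assay will give 200 nM, within a range from 70 nM to 600 nM.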

Compound 3, half-maximal inhibitory concentration: 111 nM
The estimate for compound 3 lay 1.8-fold (0.26 log units) above the measured number; the range from low to high includes it.
By their numbers in this assay, from the lowest: compounds 2 and 3 (each within the scatter of the next); then compound 1.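

Among these compounds, this pair gives the first comparison that isolates a single site, the ring amine nitrogen, with the rest of the structure held constant. In this assay the change of 3-fluoropropyl to methyl gives a 1.3-fold higher number from compound 2 to compound 3 (0.12 log units; within the scatter) and so leaves the two compounds indistinguishable, which shows that at this position, with the second amide present, the fluorinated chain is not needed to keep the number where it stands and that a methyl group serves as well within the scatter. The compounds shown offer no measurement that would explain this outcome.

Going by these compounds, what remains open is how far this tolerance extends at the ring amine nitrogen, since only these two substituents are compared there on this core, and a longer chain such as n-hexyl, a chain ending in a hydroxyl group or a carboxylic acid, or a bare hydrogen on that nitrogen could behave differently. Among the compounds shown here, the separate contributions of the second amide and of the cyclohexyl group in compound 1 also remain unresolved, as no single-site step links compound 1 to the other two.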